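The source may report more compounds than this note shows. Statements on the series, on what has been measured and on what is new or still open speak of the compounds shown alone.

In a functional assay on HeLa cells (Homo sapiens) for inhibition, read by MTT assay, with a stated time of 48 h (a higher number here means a weaker inhibitor, a lower number a stronger inhibitor), compound 1 (`Oc1ccc(C(c2c[nH]c3ccc(Br)cc23)c2c[nH]c3ccc(Br)cc23)cc1`) gives 4000 nM and compound 2 (`COc1ccc(OC)c(C(c2c[nH]c3ccc(Br)cc23)c2c[nH]c3ccc(Br)cc23)c1`) gives 5100 nM in the same test, so compound 2 stands level with compound 1 within the scatter. Next comes compound 3 (`Clc1ccc(C(c2c[nH]c3ccc(Br)cc23)c2c[nH]c3ccc(Br)cc23)cc1`), where 4-chlorophenyl takes the place of 2,5-dimethoxyphenyl on a saturated chain carbon bound to two aromatic carbons (4-chlorophenyl in place of 2,5-dimethoxyphenyl on a saturated chain carbon bound to two aromatic carbons). Going by the values given here, one measured step bears on this change: a 1.3-fold higher number from compound 1 to compound 2 (0.11 log units; within the scatter) stays within the scatter even though the aryl group differs. Among the compounds with values here, no measured compound carries 4-chlorophenyl, so this single step is thin support. In this assay no shift beyond the scatter is therefore expected, and the estimated step is a 1.3-fold lower number from compound 2 to compound 3 (0.11 log units; within the scatter) with no firm direction. Compound 3 is estimated at 4000 nM with an expected range of 1500 nM to 10000 nM in this series.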

Compound 3, half-maximal inhibitory concentration: 4800 nM
For compound 3 the middle estimate is 1.2-fold (0.08 log units) below the measured one, and the stated range covers the measured number.
By their numbers in this assay, from the lowest: compounds 1, 3 and 2 (each within the scatter of the next).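

In this assay, 4-chlorophenyl on a saturated chain carbon bound to two aromatic carbons stands level with 2,5-dimethoxyphenyl (a 1.1-fold lower number from compound 2 to compound 3 (0.03 log units; within the scatter)), and chloro in place of hydroxy on an aromatic carbon likewise leaves the result within the scatter (a 1.2-fold higher number from compound 1 to compound 3 (0.08 log units; within the scatter)). The position now holds three aryl groups with no separation beyond the scatter, and one of them, 4-chlorophenyl, has 0 hydrogen-bond donors and 0 hydrogen-bond acceptors. No measurement at hand explains this flat result.

As far as these compounds go, whether an aryl group carrying an amine or a carboxylic acid, or a longer alkyl chain in place of the aryl group, would stay level at this carbon remains open. From the compounds shown here alone, all three compounds share the core of compound 1, so what changes in that core would do also remains open.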